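A few compounds are considered here, and "the series" means these few. Any claim that something is new, unique, unknown or untested is made for them only; others in the source may bear on it.

The two measured compounds share a core that compound 1 `O=C(Nc1cccc(C(=O)O)c1O)c1ccc(/C=C2\SC(=S)N(c3ccc([N+](=O)[O-])cc3)C2=O)cc1` and compound 2 `CC(=O)c1ccc(N2C(=O)/C(=C/c3ccc(OCc4ccc(C(=O)O)cc4)cc3)SC2=S)cc1` carry in different settings. In an assay on isolated protein for inhibition of Apoptosis regulator Bcl-2 (Homo sapiens), read by fluorescence polarization (on this read-out higher numbers stand for weaker inhibition and lower numbers for stronger inhibition), compound 1 gives only a limit of the assay, > 10000 nM. Compound 2 likewise gives only a limit of the assay in this assay, > 10000 nM. Compound 2 therefore stands at the limit of > 10000 nM in this assay, at which 2 of the 2 values shown sit, and the two values show no separation between them. Compound 3 `O=C(O)c1ccc(COc2ccc(/C=C3\SC(=S)N(Cc4ccc(F)cc4)C3=O)cc2)cc1` differs from compound 2 in one place: 4-fluorobenzyl in place of 4-acetylphenyl on an amide-type nitrogen in a ring. Among the measured compounds shown here, no measured pair differing in a single place is available, so nothing shows how large such a step can be. Given that both measured values are limits, the step that the limit leaves unreadable from compound 2 to compound 3 is expected to be no change beyond the scatter. Compound 3 is accordingly estimated at 15000 nM, within 4000 nM to 60000 nM, most likely reported again only as a limit.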

Compound 3, inhibition constant: > 10000 nM
Compound 3 ended at the assay's limit; the forecaster's own chance of this, stated with the estimate: 75%; the middle value does not contradict the limit.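

Compound 2 and compound 3 both give only a limit in this assay, so no step can be read between them: the limit of > 10000 nM in this assay, at which 3 of the 3 values shown sit.

The compounds shown leave open how far a change in one place can shift inhibition, since none of them gives a readable value in this assay.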